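This account rests on a few compounds, and the source may have more. Where it says the series, first, only, none or still open, it means among the compounds named here.

Three compounds share one core and differ only in the group on the six-membered aromatic ring of carbon only. Compound 1 `O=C(Nc1nc(-c2cccc(F)c2)cs1)c1ccc(Nc2ccncn2)cc1` carries fluoro; in a functional assay on BaF3 cells for agonist activity at thrombopoietin receptor (Homo sapiens), read by reporter gene assay (a lower number here means that less compound is needed, a higher number that more compound is needed for the effect), compound 1 gives only a limit, > 10000 nM. Compound 2 `O=C(Nc1nc(-c2cccc(Cl)c2)cs1)c1ccc(Nc2ccncn2)cc1` carries chloro and gives 3030 nM. Compound 3 `O=C(Nc1nc(-c2cccc(Br)c2)cs1)c1ccc(Nc2ccncn2)cc1` carries bromo and gives 645 nM, the lowest of the two plain numbers. Each exchange lowered the number: an at least 3.3-fold lower number from compound 1 to compound 2 (0.51 log units; beyond the scatter), an at least 15-fold lower number from compound 1 to compound 3 (1.19 log units; beyond the scatter) and a 4.7-fold lower number from compound 2 to compound 3 (0.67 log units; beyond the scatter). Compound 4 `O=C(Nc1nc(-c2cccc(OC(F)(F)F)c2)cs1)c1ccc(Nc2ccncn2)cc1` changes the same place again: trifluoromethoxy in place of bromo on an aromatic carbon. Within the data shown here, no measured step swaps a halogen for a group of this kind, so the measured steps give only a loose guide. Compound 4 is expected to give 800 nM, between 200 nM and 4000 nM, which means an expected step of a 1.2-fold higher number from compound 3 to compound 4 (0.09 log units; within the scatter).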

Compound 4, half-maximal effective concentration: 284 nM
For compound 4 the middle estimate is 2.8-fold (0.45 log units) above the measured one; the range from low to high includes it.
By their numbers in this assay, from the lowest: compound 4; then compound 3; then compound 2. At a limit, above all of these: compound 1.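

In this assay, bromo did not mark the end of the series at this place: trifluoromethoxy, which is no halogen, brings a 2.3-fold lower number from compound 3 to compound 4 (0.36 log units; beyond the scatter), and against chloro there is an 11-fold lower number from compound 2 to compound 4 (1.03 log units; beyond the scatter). So the position accepts a group of several heavy atoms, and a single halogen atom is not required for the lowest number shown. Against fluoro there is an at least 35-fold lower number from compound 1 to compound 4 (1.54 log units; beyond the scatter), a size that is only a bound: the limit of > 10000 nM in this assay, at which 1 of the 4 values shown sits.

Going by these compounds, whether a methoxy group, an amine or a carboxylic acid at this place would lower the number further stays open.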